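This account rests on a few compounds, and the source may have more. Where it says the series, first, only, none or still open, it means among the compounds named here.

Cytotoxicity tests ask how much of a compound it takes to harm cells. In an ADME assay on HFF cells (Homo sapiens) for cytotoxicity, read by neutral red uptake (on this read-out higher numbers stand for lower toxicity in this test and lower numbers for higher toxicity in this test), compound 1 (`Nc1ncnc2c1ncn2/C=C1/C[C@@H]1[C@H](O)CO`) gives > 300000 nM, which is a limit of the assay and not a number. Within the data shown here, this limit is the only information on compound 1, as the limit of > 300000 nM in this assay, at which 1 of the 2 values shown sits, shows. Among the measured compounds shown here, the only other measured compound, compound 2 (`Nc1nc2c(ncn2/C=C2\C[C@H]2[C@@H](O)CO)c(=O)[nH]1`), gives 298000 nM, a true number.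

The compound still to be measured is compound 3 (`Nc1ncnc2c1ncn2/C=C1/C[C@H]1[C@@H](O)CO`). The change from compound 1 is the two compounds have the same atoms and bonds and differ only in configuration as drawn: 2 of 3 stereo elements differ; a stereocentre at a saturated ring carbon is drawn S in compound 1 and R in compound 3; a stereocentre at a saturated chain carbon is drawn S in compound 1 and R in compound 3. No atoms leave or enter, so the difference lies only in the configuration as drawn, at a saturated ring carbon and at a saturated chain carbon.

For the measured compounds named here, no measured pair shows what such a change does in this assay, so the expectation is modest: no step beyond the usual scatter, in either direction. The estimated at least 1.0-fold lower number from compound 1 to compound 3 (0.02 log units; that floor lies within the scatter) is therefore small, and the assay may again report only a limit. For compound 3, the expected value is 280000 nM, with an estimated range from 130000 nM to 400000 nM.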

Compound 3, half-maximal cytotoxic concentration: 194000 nM
The estimate for compound 3 lay 1.4-fold (0.16 log units) above the measured number; the measured number falls inside the stated range.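

In this assay, moving the saturated ring carbon and the saturated chain carbon from S to R gives an at least 1.5-fold lower number from compound 1 to compound 3 (0.18 log units; that floor lies within the scatter). Among these compounds, this is the first step in this test that can be read at all, and it rests on a pair of compounds with the same atoms and bonds. As far as these compounds go, for compound 1 the test gives a limit and not a number, so the step is only a floor, and its true size stays unknown: the limit of > 300000 nM in this assay, at which 1 of the 3 values shown sits. Any real gap between the two compounds could come only from the configuration, because of one fact: the fact that compounds 1 and 3 differ only in the configuration as drawn.

The compounds shown do not separate the saturated ring carbon from the saturated chain carbon, since both stereocentres differ together, so neither can be given its own share of any gap. They also say nothing about how an amine or a carboxylic acid in place of a hydroxyl group would read in this assay.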